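This account rests on a few compounds, and the source may have more. Where it says the series, first, only, none or still open, it means among the compounds named here.

Measured so far in an assay on isolated protein for inhibition of malate dehydrogenase, mitochondrial (Sus scrofa), with stated times of 45 min and 30 min; on this read-out higher numbers stand for weaker inhibition and lower numbers for stronger inhibition:
Compound 1 `O=S(=O)(Nc1ccc(-c2nc3ccccc3o2)cc1)c1cccc(F)c1` gives > 63000 nM, which is a limit of the assay rather than a number.
Compound 2 `O=S(=O)(Nc1ccc(-c2nc3ccccc3o2)cc1)c1ccccc1F` gives > 63000 nM, also a limit.
Compound 3 `O=S(=O)(Nc1ccc(-c2nc3ccccc3o2)cc1)c1ccccc1O` gives > 63000 nM, also a limit.

All three values sit at the same limit (the limit of > 63000 nM in this assay, at which 3 of the 3 values shown sit), so compound 1 stands nowhere in particular among them: no measured number sets it apart. The steps a step that the two limits leave unreadable from compound 1 to compound 2, a step that the two limits leave unreadable from compound 1 to compound 3 and a step that the two limits leave unreadable from compound 2 to compound 3 are all unreadable, since both ends of each rest on a limit.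

Compound 4 `O=S(=O)(Nc1ccc(-c2nc3ccccc3o2)cc1)c1cccc(C(F)(F)F)c1` differs from compound 1 by trifluoromethyl in place of fluoro on an aromatic carbon. Every change measured so far left the value at the limit, so compound 4 is expected to do the same, and the step that the limit leaves unreadable from compound 1 to compound 4 is expected to be nothing that the assay can read. The estimate for compound 4 is 100000 nM, expected between 30000 nM and 500000 nM, most likely reported again only as a limit.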

Compound 4, half-maximal inhibitory concentration: > 63000 nM
Compound 4 gave a limit, no number; the forecaster's own chance of this, stated with the estimate: 85%; the middle value lies beyond the limit too.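

Compound 1 and compound 4 both rest on a limit, so no size can be read for the step between them: the limit of > 63000 nM in this assay, at which 4 of the 4 values shown sit.

The compounds shown leave open which change, if any, would bring a value off this limit and give a real number.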